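The source may report more compounds than this note shows. Statements on the series, on what has been measured and on what is new or still open speak of the compounds shown alone.

Measured so far in an assay on Sf9 cells for inhibition of Leucine-rich repeat serine/threonine-protein kinase 2 (Homo sapiens), read by TR-FRET, with stated times of 30 min and 2 h; a higher number here means a weaker inhibitor, a lower number a stronger inhibitor:
compound 1 `CN1CCN(c2ccc(OCc3ccccc3)c(C(=O)Nc3ccnnc3)c2)CC1` gives 12.6 nM
compound 2 `N#CC1CCN(c2ccc(OCc3ccccc3)c(C(=O)Nc3ccnnc3)c2)CC1` gives 10 nM

Compound 2 holds the lowest of the two numbers, but the step of a 1.3-fold lower number from compound 1 to compound 2 (0.10 log units; within the scatter) lies within the scatter, so the two compounds are not told apart. Compound 3 `CN1CC2(CCN(c3ccc(OCc4ccccc4)c(C(=O)Nc4ccnnc4)c3)CC2)C1` carries a group of 10 heavy atoms (8 carbon, 2 nitrogen; one four-membered non-aromatic ring with 1 hetero atom, one six-membered non-aromatic ring with 1 hetero atom) in place of a group of 8 heavy atoms (6 carbon, 2 nitrogen; one six-membered non-aromatic ring with 1 hetero atom), on an aromatic carbon. Among the compounds with values here, the only measured step, a 1.3-fold lower number from compound 1 to compound 2 (0.10 log units; within the scatter), exchanged one ring at that same position for another and stayed within the scatter; nothing measured bears more closely on this change. No step beyond the scatter in this assay is therefore expected, the estimated step being a 1.2-fold higher number from compound 2 to compound 3 (0.08 log units; within the scatter). Compound 3 is expected to give 12 nM, in the range 4 nM to 40 nM.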

Compound 3, half-maximal inhibitory concentration in the Leucine-rich repeat serine/threonine-protein kinase 2 assay: 63.1 nM
Beside the measured number, compound 3's estimate is 5.3-fold (0.72 log units) below it, outside the stated range (above it).
By their numbers in the Leucine-rich repeat serine/threonine-protein kinase 2 assay, from the lowest: compounds 2 and 1 (each within the scatter of the next); then compound 3.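

In the Leucine-rich repeat serine/threonine-protein kinase 2 assay this position proves sensitive to the group it carries, which the first ring exchange did not show: a 6.3-fold higher number from compound 2 to compound 3 (0.80 log units; beyond the scatter), and a 5.0-fold higher number from compound 1 to compound 3 (0.70 log units; beyond the scatter). Within the data shown here, the group with a four-membered ring is the first change here to give a weaker inhibitor, so tolerance at this position does not extend to every ring group. Compound 3 also parts from compound 2 in a physicochemical assay for lipophilicity, at pH 7.4; on this read-out higher numbers stand for higher lipophilicity and lower numbers for lower lipophilicity: the measured distribution coefficient of compound 2, 4.5, and of compound 3, 2.2, a number 2.30 log units lower (beyond the scatter)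

In the physicochemical assay compound 2 gives 4.5 and compound 3 gives 2.2 on this read-out.

Three compounds cannot separate the effect of the four-membered ring from that of group size or lipophilicity. Going by these compounds, how a morpholin-4-yl group would read at this position remains open.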